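A third methoxy on compound 1's ring

This account rests on a few compounds, and the source may have more. Where it says the series, first, only, none or still open, it means among the compounds named here.

Values in a functional assay on HaCaT cells (Homo sapiens) for inhibition, read by sulforhodamine B assay, with a stated time of 48 h (on this read-out lower numbers stand for stronger inhibition of growth and higher numbers for weaker inhibition of growth), so far:
Compound 1 `COc1ccc(/C=C/C2(C)C=CC(=O)O2)cc1OC` gives 838000 nM
Compound 2 `COc1ccc(/C=C/C2(C)C=CC(=O)O2)c(OC)c1OC` gives 217000 nM
Compound 3 `COc1cc(OC)c(OC)cc1/C=C/C1(C)C=CC(=O)O1` gives 180000 nM

Compound 1 stands highest of the three, so it shows the weakest growth inhibition here. Compound 4 `COc1cc(/C=C/C2(C)C=CC(=O)O2)cc(OC)c1OC` has not yet been measured. It departs from compound 1 by one change: methoxy in place of hydrogen on an aromatic carbon. Two measured steps make the same kind of replacement at other ring places: a 3.9-fold lower number from compound 1 to compound 2 (0.59 log units; beyond the scatter) and a 4.7-fold lower number from compound 1 to compound 3 (0.67 log units; beyond the scatter). Both are modest, beyond the scatter, and point the same way. As far as these compounds go, a similar modest drop is therefore expected in this assay, although this third placement is untested. The expected step is a 4.0-fold lower number from compound 1 to compound 4 (0.60 log units; beyond the scatter). For compound 4 the estimate is 210000 nM, with an expected range of 90000 nM to 480000 nM.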

Compound 4, concentration for total growth inhibition: 175000 nM
The estimate for compound 4 lay 1.2-fold (0.08 log units) above the measured number, and the stated range covers the measured number.
By their numbers in this assay, from the lowest: compounds 4, 3 and 2 (each within the scatter of the next); then compound 1.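

In this assay, methoxy in place of hydrogen on the aromatic carbon ortho to a methoxy group and meta to the group of 9 heavy atoms gives a 4.8-fold lower number from compound 1 to compound 4 (0.68 log units; beyond the scatter). This third placement therefore also lowers the number, and its step is modest, like the two earlier ones, so this position shows no distinct gain in this set. No measured evidence bears on why this replacement lowers the number. The compounds shown leave open whether an amine, a hydroxyl or a longer chain such as ethoxy at this position would give a similar step.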